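A few compounds are considered here, and "the series" means these few. Any claim that something is new, unique, unknown or untested is made for them only; others in the source may bear on it.

Compound 1 `COc1ccc2nc(C)cc(OCC(=O)Nc3cc(C)cc(C)c3)c2c1` gives a limit in an ADME assay on microsomes from liver (Homo sapiens) for metabolic stability, read by LC-MS, using NADPH, with a stated time of 30 min, tested at 0.5 uM (on this read-out higher numbers stand for a longer-lived compound and lower numbers for a shorter-lived compound), not a number: > 0.5 h
Compound 2 `Cc1cc(C)cc(NC(=O)COc2cc(C)nc3ccc(C)cc23)c1` likewise gives only a limit in this assay: > 0.5 h

Compound 1 therefore stands only at the limit of > 0.5 h in this assay, at which 2 of the 2 values shown sit, and the step that the two limits leave unreadable from compound 1 to compound 2 cannot be read. Compound 3 `COc1ccc2nc(C)cc(OCC(=O)Nc3cccc(C)c3)c2c1` differs from compound 1 by hydrogen in place of methyl on an aromatic carbon. Within the data shown here, no measured step bears on this change; what is known is that both measured compounds sit at the same limit. Compound 3 is thus expected to reach that limit as well, the step that the limit leaves unreadable from compound 1 to compound 3 being estimated as none beyond the scatter. The estimate for compound 3 is 1 h, with a range from 0.4 h to 3 h.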

Compound 3, half-life: 0.383 h
Compound 3: the middle estimate sits 2.6-fold (0.42 log units) above what was measured; measured number outside the range, below it.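

Hydrogen in place of methyl on this aromatic carbon gives an at least 1.3-fold lower number from compound 1 to compound 3 (0.11 log units; that floor lies within the scatter) in this assay. Compound 3 is the only compound shown with a number rather than a limit, and the true gap to compound 1 may be larger than this floor. The rest of the series gives no number: the limit of > 0.5 h in this assay, at which 2 of the 3 values shown sit.

On these data alone, the step from compound 1 to compound 2 cannot be read, and how far either compound lies past its limit stays open. Also open, as far as these compounds go, is what an amine, a carboxylic acid or a longer chain would do at this ring position.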